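Thiourea series: cytotoxicity notes toward compound 4

The source may report more compounds than this note shows. Statements on the series, on what has been measured and on what is new or still open speak of the compounds shown alone.

Measured so far in an ADME assay on Huh-7 cells (Homo sapiens) for cytotoxicity; on this read-out higher numbers stand for lower toxicity in this test and lower numbers for higher toxicity in this test:
compound 1, `NC(=S)Nc1cccc(OCCCCCc2ccccc2)c1`, gives 22000 nM
compound 2, `NC(=S)Nc1cccc(OCCCCCCCCNC(=S)Nc2cccc(Br)c2)c1`, gives 20000 nM
compound 3, `NC(=S)Nc1cccc(OCCCCCCCCNC(=S)Nc2ccccc2Br)c1`, gives 36000 nM

In this assay compound 3 holds the highest of the three numbers, yet its gaps to compound 1 and to compound 2 are both within the scatter, so the three measured compounds are not distinguishable on this read-out. Going by the values given here, the only single-point step among them, a 1.8-fold higher number from compound 2 to compound 3 (0.26 log units; within the scatter), is likewise within the scatter.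

Compound 4, `NC(=S)Nc1cccc(OCCCCCCCCNC(=S)Nc2ccc3c(c2)CCC3)c1`, is the next member. It differs from compound 3 in one place: 2,3-dihydro-1H-inden-5-yl in place of 2-bromophenyl on an amide-type nitrogen. Among the compounds with values here, no measured step touches that aryl replacement itself; the nearest comparison is the bromophenyl swap on the same amide-type nitrogen, which produced no step beyond the scatter. Compound 1, which lacks the second thiourea altogether, also sits within the scatter of compound 2 and compound 3, so the measured set gives no case of a change at that end of the chain moving the number.

Accordingly the step of a 1.3-fold lower number from compound 3 to compound 4 (0.11 log units; within the scatter) is expected to stay within the scatter, in no clear direction. The estimate for compound 4 in this assay is 28000 nM, with a range from 12000 nM to 65000 nM.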

Compound 4, half-maximal cytotoxic concentration: 34000 nM
Estimate against measurement, compound 4: 1.2-fold (0.08 log units) below; the range from low to high includes it.
By their numbers in this assay, from the lowest: compounds 2, 1, 4 and 3 (each within the scatter of the next).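

The earlier compounds shown here only moved a bromine on a phenyl ring, whereas this change removes the bromine and adds a second ring at the same amide-type nitrogen. With 2,3-dihydro-1H-inden-5-yl in place of 2-bromophenyl, this assay shows a 1.1-fold lower number from compound 3 to compound 4 (0.02 log units; within the scatter); with the same group in place of 3-bromophenyl, it shows a 1.7-fold higher number from compound 2 to compound 4 (0.23 log units; within the scatter). Both steps lie within the scatter, so at this position the read-out does not separate the carbon-only group of 9 heavy atoms, with its five-membered non-aromatic ring, from either bromophenyl group, and no supporting data bear on this result.

On these data alone, whether any replacement on this nitrogen can move the number beyond the scatter remains open, for example a phenyl ring carrying a carboxylic acid or an amine. Also open, as far as these compounds go, is how a longer chain between the two thioureas would read in this assay when paired with the 2,3-dihydro-1H-inden-5-yl group.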